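Solubility: replacing a piperidinylmethyl group with a small amide

A few compounds are considered here, and "the series" means these few. Any claim that something is new, unique, unknown or untested is made for them only; others in the source may bear on it.

Compound 1 `O=C1O[C@@H](CN2CCCCC2)CN1c1ccc(-n2cc(-c3ccccn3)cn2)c(F)c1` gives 219000 nM in a physicochemical assay for solubility, read by HPLC, with a stated time of 24 h; a higher number here means a more soluble compound, a lower number a less soluble compound.
Compound 2 `O=C1O[C@@H](CN2CCC(O)CC2)CN1c1ccc(-n2cc(-c3ccccn3)cn2)c(F)c1` gives 45900 nM in this assay.
Compound 3 `CNC(=O)[C@H]1CN(c2ccc(-n3cc(-c4ccccn4)cn3)c(F)c2)C(=O)O1` gives 26200 nM in this assay.

Compound 2 stands second highest of the three numbers: compound 1 is a 4.8-fold lower number from compound 1 to compound 2 (0.68 log units; beyond the scatter) apart, while compound 3 lies a 1.8-fold lower number from compound 2 to compound 3 (0.24 log units; within the scatter) away. Compound 4 `CONC(=O)[C@H]1CN(c2ccc(-n3cc(-c4ccccn4)cn3)c(F)c2)C(=O)O1` is not yet measured. It differs from compound 2 as follows: methoxycarbamoyl in place of (4-hydroxypiperidin-1-yl)methyl on a saturated ring carbon.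

The closest measured step is a 1.8-fold lower number from compound 2 to compound 3 (0.24 log units; within the scatter), which swaps in a closely related small amide. By analogy, compound 4 is expected to sit near compound 3, with a 1.8-fold lower number from compound 2 to compound 4 (0.26 log units; within the scatter) as the estimated step. Compound 4 is therefore estimated at 25000 nM, within a range from 8000 nM to 70000 nM.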

Compound 4, solubility: 78100 nM
For compound 4 the middle estimate is 3.1-fold (0.49 log units) below the measured one; measured number outside the range, above it.
By their numbers in this assay, from the lowest: compounds 3, 2 and 4 (each within the scatter of the next, the first and the last beyond it); then compound 1.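

At this position on the shared core, a small edit inside the amide matters: methoxy in place of methyl on the amide-type nitrogen gives a 3.0-fold higher number from compound 3 to compound 4 (0.47 log units; beyond the scatter) in this assay while the rest of the molecule stays the same. The methoxycarbamoyl group, which has no ring, stands level with the (4-hydroxypiperidin-1-yl)methyl group, with a 1.7-fold higher number from compound 2 to compound 4 (0.23 log units; within the scatter) as the step, but not with the (piperidin-1-yl)methyl group, where the step is a 2.8-fold lower number from compound 1 to compound 4 (0.45 log units; beyond the scatter) and lies beyond the scatter. Nothing measured here explains these differences.

As far as these compounds go, whether an ethoxy group or a free hydroxy group on the amide nitrogen would behave like methoxy stays open, as does the result of a carboxylic acid on this ring carbon.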